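The source may hold more compounds than are shown below. What is called first, only, known or untested is meant among the compounds shown, and "the series" means these compounds.

Measured compounds:
Compound 1 `COc1cc(N2C(N)=C(C#N)C(/C=C/c3ccccc3)C3=C2CC(C)(C)CC3=O)cc(OC)c1OC` gives 10% in a functional assay on Ehrlich cells (Mus musculus) for cytotoxicity, tested at 10 ug/mL; a higher number here means a stronger effect of the compound at the concentration tested, a lower number a weaker effect.
Compound 2 `COc1cc(N2C(N)=C(C#N)C(c3ccc(OC)c4ccccc34)C3=C2CC(C)(C)CC3=O)cc(OC)c1OC` gives 10% in this assay.

Compound 2 stands level with compound 1 at the digits shown, and the one measured step, no change at the digits printed from compound 1 to compound 2 (within the scatter), lies within the scatter. Compound 3 `COc1cc(N2C(N)=C(C#N)C(c3c(O)ccc4ccccc34)C3=C2CC(C)(C)CC3=O)cc(OC)c1OC` differs from compound 2 by 2-hydroxynaphthalen-1-yl in place of 4-methoxynaphthalen-1-yl on a saturated ring carbon. Going by the values given here, the only step that bears on this change is the earlier aryl replacement on the same carbon, which left the read-out unchanged, so no step beyond the scatter is expected, no change at the digits printed from compound 2 to compound 3 (within the scatter). Compound 3 is therefore estimated at 10%, within a range from 0% to 25%.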

Compound 3, a percentage reported as activity, at one concentration (the size of the read-out at that concentration, not a potency): 2%
Estimate against measurement, compound 3: 8 percentage points above, and the stated range covers the measured number.
By their numbers in this assay, from the lowest: compounds 3, 1 and 2 (each within the scatter of the next).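

On this saturated ring carbon, 2-hydroxynaphthalen-1-yl, the only group shown here with a hydrogen-bond donor, does not separate from the other two groups in this assay: the change gives a number 8 percentage points lower from compound 2 to compound 3 (within the scatter), and against 2-phenylethenyl it gives a number 8 percentage points lower from compound 1 to compound 3 (within the scatter). The three groups shown on this carbon therefore remain indistinguishable in this read-out, and no evidence bearing on this result is available. From the compounds shown here alone, whether an amine or a carboxylic acid on this carbon would give a step beyond the scatter remains open, as does the effect of changing the 3,4,5-trimethoxyphenyl group.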